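The source may hold more compounds than are shown below. What is called first, only, known or untested is meant among the compounds shown, and "the series" means these compounds.

In a functional assay on K562 cells (Homo sapiens) for cytotoxicity, read by trypan blue exclusion, with a stated time of 96 h (a lower number here means a stronger inhibitor, a higher number a weaker inhibitor), compound 1 (`COc1ccc(CS(=O)(=O)/C=C/c2cc(OC)c(OC)c(OC)c2)cc1N`) gives 250 nM, while compound 2 (`COc1cc(OC)c(/C=C/[S+]([O-])Cc2ccc(OC)c([N+](=O)[O-])c2)c(OC)c1`) gives 15000 nM, the higher of the two numbers and beyond the scatter from compound 1. Compound 3 (`COc1cc(OC)c(/C=C/[S+]([O-])Cc2ccc(OC)c(N)c2)c(OC)c1`) has amino in place of nitro on an aromatic carbon of compound 2: amino in place of nitro on an aromatic carbon. For the measured compounds named here, no measured pair shows this change alone. Compound 1, which also carries an amino group, gives 250 nM, and this points towards a lower number. The expected step is a 13-fold lower number from compound 2 to compound 3 (1.10 log units; beyond the scatter), a fall beyond the scatter. For compound 3 the estimated value is 1200 nM, within an expected range of 200 nM to 7000 nM.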

Compound 3, half-maximal inhibitory concentration: 20 nM
The estimate for compound 3 lay 60-fold (1.78 log units) above the measured number; measured number below the stated range.
By their numbers in this assay, from the lowest: compound 3; then compound 1; then compound 2.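

In this assay, amino in place of nitro on this aromatic carbon, ortho to a methoxy group, gives a 750-fold lower number from compound 2 to compound 3 (2.88 log units; beyond the scatter), a large step beyond the scatter. For the compounds shown here, the earlier compounds differ in more than one place, so only this pair shows the change alone. Nothing shown here accounts for the size of this step. The compounds shown leave open whether a hydroxyl group or an acetamide at this position would stay as close to compound 3 in this assay. They also leave open whether the same change on the core of compound 1 would give a step of similar size.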